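This account rests on a few compounds, and the source may have more. Where it says the series, first, only, none or still open, it means among the compounds named here.

In an assay on HEK293 cells for activation of potassium channel subfamily T member 1 (Homo sapiens), read by thallium flux (on this read-out higher numbers stand for an effect only at larger amounts of compound and lower numbers for an effect already at smaller amounts), compound 2, with the structure `CC1CCN(S(=O)(=O)N2CCN(CC(=O)Nc3cccc(Cl)c3)CC2)CC1`, gives 7600 nM. For the measured compounds named here, this is the only number in the set: the other value is a limit. Compound 1, with the structure `COc1ccc(Cl)cc1NC(=O)N1CC2(CCN(S(=O)(=O)N3CCC(C)CC3)CC2)C1`, is reported in this assay only as > 10000 nM, which is a limit of the assay and not a number, matching (the limit of > 10000 nM in this assay, at which 1 of the 2 values shown sits). Compound 3, with the structure `CC1CCN(S(=O)(=O)N2CCN(CC(=O)Nc3cc(Cl)ccc3F)CC2)CC1`, is not yet measured in this assay. Compound 3 differs from compound 2 by fluoro in place of hydrogen on an aromatic carbon. Going by the values given here, no measured pair in this set shares that difference, so there is nothing here to size the step from. Compound 3 is therefore expected to sit close to compound 2, with a step of a 1.3-fold lower number from compound 2 to compound 3 (0.10 log units; within the scatter) that need not exceed the usual scatter. The estimate for compound 3 in this assay is 6000 nM, within a range from 2000 nM to 20000 nM.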

Compound 3, half-maximal effective concentration: 3800 nM
Compound 3: the middle estimate sits 1.6-fold (0.20 log units) above what was measured; measured number inside the range.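

In this assay, for the compounds shown here, this is the first step in the set that can be read as a number: a 2.0-fold lower number from compound 2 to compound 3 (0.30 log units; within the scatter). Going by these compounds alone, at this position, on an aromatic carbon ortho to a large group and para to a chloro group, fluoro in place of hydrogen leaves compound 3 and compound 2 indistinguishable, so the single step shows no effect that can be told from the scatter. Nothing shown gives a reason for this result.

From the compounds shown here alone, whether a nitrile, a trifluoromethyl group or an amine on the same aromatic carbon would move the number beyond the scatter remains open. Also open, going by these compounds, is how the 5-chloro-2-fluorophenyl group would read on the core of compound 1, which is known here only through a limit.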